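The source may report more compounds than this note shows. Statements on the series, on what has been measured and on what is new or still open speak of the compounds shown alone.

In a functional assay on CHO.K1 cells for antagonist activity at prostaglandin D2 receptor 2 (Homo sapiens), read by GTPgammaS binding, with a stated time of 1 h (a higher number here means a weaker inhibitor, a lower number a stronger inhibitor), compound 2 `Cc1c(Cc2ccccc2S(=O)(=O)c2ccc(F)cc2)c2c(n1CC(=O)O)CCNC2=O` gives 3.3 nM, the lowest of the three numbers measured, though the step of a 1.2-fold lower number from compound 1 to compound 2 (0.08 log units; within the scatter) from compound 1 `Cc1c(Cc2ccccc2S(=O)(=O)c2cccc(Cl)c2)c2c(n1CC(=O)O)CCNC2=O`, with its value of 4 nM, stays within the scatter. Compound 3 `COc1ccc(S(=O)(=O)c2ccc(F)cc2)c(Cc2c3c(n(CC(=O)O)c2C)CCNC3=O)c1` gives 7.1 nM in this assay, and the step of a 2.2-fold higher number from compound 2 to compound 3 (0.33 log units; beyond the scatter) is the only one among the three that reaches beyond the scatter.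

Compound 4 `CCS(=O)(=O)c1ccccc1Cc1c2c(n(CC(=O)O)c1C)CCNC2=O` has not been measured. It differs from compound 2 by ethyl in place of 4-fluorophenyl on a sulfonyl sulfur. For the measured compounds named here, of the measured steps, only the one from compound 1 to compound 2 touches the same sulfonyl sulfur, and there the swap of one substituted phenyl for another gave a 1.2-fold lower number from compound 1 to compound 2 (0.08 log units; within the scatter). The methoxy step from compound 2 to compound 3 sits elsewhere and is modest. Going by the values given here, no measured pair shows what the loss of a whole aromatic ring at this sulfur does, so the expectation rests on little; a shift toward a higher number in this assay seems more likely than none. For compound 4 the estimate is 15 nM, with a range from 4 nM to 60 nM, which corresponds to an expected step of a 4.5-fold higher number from compound 2 to compound 4 (0.66 log units; beyond the scatter).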

Compound 4, half-maximal inhibitory concentration: 550 nM
Compound 4: middle estimate off by 37-fold (1.56 log units), on the low side; measured number outside the range, above it.
By their numbers in this assay, from the lowest: compounds 2, 1 and 3 (each within the scatter of the next, the first and the last beyond it); then compound 4.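

In this assay the change to ethyl on the sulfonyl sulfur gives a 170-fold higher number from compound 2 to compound 4 (2.22 log units; beyond the scatter) and, starting from 3-chlorophenyl instead, a 140-fold higher number from compound 1 to compound 4 (2.14 log units; beyond the scatter) as well, so a place that hardly registered the exchange of one substituted phenyl for another responds strongly once the aromatic ring is gone. Both steps are large and point the same way, so the result does not depend on which of the two phenyl compounds serves as the reference. Nothing available here explains why the loss is so large.

For the compounds shown here, whether the aromatic ring itself matters or any larger carbon group would do remains open, since ethyl is the only group without a ring at this sulfur. A cyclohexyl group, a benzyl group or a pyridine ring there would help separate these possibilities.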